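Methoxy in Place of Hydrogen: Expected Cytotoxicity of Compound 3

The source may report more compounds than this note shows. Statements on the series, on what has been measured and on what is new or still open speak of the compounds shown alone.

Of the compounds shown here, two sharing one core have been tested in an ADME assay on HEK293 cells (Homo sapiens) for cytotoxicity, read by MTT assay, with a stated time of 24 h; a higher number here means a weaker inhibitor, a lower number a stronger inhibitor. Compound 1 `CN1CCN(CCCNc2nc3cc([N+](=O)[O-])ccc3nc2NCc2ccc(C(F)(F)F)cc2)CC1` gives 9.53 ug/mL. Compound 2 `CN(C)CCCNc1nc2cc([N+](=O)[O-])ccc2nc1NCc1ccccc1` gives 2.74 ug/mL, the lower of the two numbers, and compound 1 sits higher by a gap beyond the usual scatter. Compound 3 `COc1ccccc1CNc1nc2ccc([N+](=O)[O-])cc2nc1NCCCN(C)C` is not yet measured. It differs from compound 2 in one place: methoxy in place of hydrogen on an aromatic carbon. For the measured compounds named here, no step between measured compounds shows how such a change acts here. A small change of this kind is expected to shift the number in this assay little, if at all, beyond the scatter. The expected step is a 1.1-fold higher number from compound 2 to compound 3 (0.04 log units; within the scatter). Compound 3 is therefore estimated at 3 ug/mL, within a range from 1.4 ug/mL to 6.5 ug/mL.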

Compound 3, half-maximal inhibitory concentration: 36.1 ug/mL
Beside the measured number, compound 3's estimate is 12-fold (1.08 log units) below it; measured number outside the range, above it.
By their numbers in this assay, from the lowest: compound 2; then compound 1; then compound 3.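

Turning benzyl into 2-methoxybenzyl is the first single change seen in this series, and in this assay it gives a 13-fold higher number from compound 2 to compound 3 (1.12 log units; beyond the scatter). This aromatic carbon is therefore not a place where a small group passes unnoticed: adding methoxy here makes compound 3 a much weaker inhibitor than compound 2. Nothing measured here explains the size of this step. On these data alone, it remains open whether the step belongs to methoxy itself or would also appear with a smaller group, such as a fluorine atom or a hydroxyl group, at this same place.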